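Lengthening the Tetrazole Tether on Compound 2

The compounds below may be only part of what the source reports. "The series", "measured", "known", "first", "only" and "open" are said of these compounds alone.

Three compounds share a core in which a quinoline-derived ether is linked to a benzene ring bearing a tetrazole. In a functional assay (Cavia porcellus) for inhibition of cysteinyl leukotriene receptor (Homo sapiens) (on this read-out lower numbers stand for stronger inhibition and higher numbers for weaker inhibition), compound 1 `c1cc(OCc2ccc3ccccc3n2)cc(-c2nn[nH]n2)c1` gives 200 nM and compound 2 `c1cc(OCc2ccc3ccccc3n2)cc(OCc2nn[nH]n2)c1` gives 140 nM. Compound 3 `c1ccc2nc(COc3ccc(SCCCc4nnn[nH]4)cc3)ccc2c1` gives 25 nM in this assay. Among these three numbers compound 2 stands second highest, close to compound 1 and well apart from compound 3, which gives the lowest number.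

The step of a 1.4-fold lower number from compound 1 to compound 2 (0.15 log units; within the scatter) shows that moving the tetrazole out by one carbon changed little. Compound 4 `c1cc(OCCCCc2nnn[nH]2)cc(OCc2ccc3ccccc3n2)c1` goes further along the same line: 3-(1H-tetrazol-5-yl)propyl in place of 2H-tetrazol-5-yl on a saturated chain carbon bound to an oxygen on an aromatic ring. Within the data shown here, no measured step covers this exact change, but compound 3, in which a three-carbon chain separates the ring and the tetrazole, gives a markedly lower number than compound 2 in this assay. A modest move toward a lower number, a 1.8-fold lower number from compound 2 to compound 4 (0.24 log units; within the scatter), is therefore expected, with wide uncertainty. Compound 4 is estimated at 80 nM, in a range from 25 nM to 250 nM.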

Compound 4, half-maximal inhibitory concentration: 120 nM
The estimate for compound 4 lay 1.5-fold (0.18 log units) below the measured number; the range from low to high includes it.
By their numbers in this assay, from the lowest: compound 3; then compounds 4, 2 and 1 (each within the scatter of the next).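

In this assay the longer 3-(1H-tetrazol-5-yl)propyl in place of 2H-tetrazol-5-yl on a saturated chain carbon bound to an oxygen on an aromatic ring makes no difference beyond the scatter (a 1.2-fold lower number from compound 2 to compound 4 (0.07 log units; within the scatter)). Among these compounds, this position therefore accepts a much longer chain carrying the tetrazole without the number moving beyond the scatter, which the single short step from compound 1 to compound 2 could not show. Nothing measured here offers a reason for this flat result.

Compound 3 differs from compound 4 in more than one place. The two compounds are therefore not compared here. As far as these compounds go, whether a still longer chain at this position, or a carboxylic acid in place of the tetrazole, would shift the number stays open.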